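This account rests on a few compounds, and the source may have more. Where it says the series, first, only, none or still open, it means among the compounds named here.

Measured so far in a functional assay on SW480 cells (Homo sapiens) for cytotoxicity, read by sulforhodamine B assay, with a stated time of 48 h; on this read-out higher numbers stand for weaker inhibition and lower numbers for stronger inhibition:
- compound 1, `COc1ccc(/C=C/C(=O)c2ccc(N)c(-c3ccc(F)cc3)c2)cc1OC`: 6640 nM
- compound 2, `O=C(/C=C/c1cccc(Br)c1)c1cccc(-c2cccc(F)c2)c1`: 8610 nM

Compound 2 has the higher of the two numbers, yet its gap to compound 1 lies within the scatter, so the two compounds cannot be set in order on this assay. Among the compounds with values here, no step between measured compounds is recorded. Compound 3, `COc1ccccc1/C=C/C(=O)c1cccc(-c2cccc(F)c2)c1`, differs from compound 2 in one place: 2-methoxyphenyl in place of 3-bromophenyl on a double-bonded chain carbon bound to a double-bonded chain carbon. Nothing measured here shows what this change does, so no step beyond the scatter is expected in this assay; the step from compound 2 to compound 3 is estimated as a 1.1-fold lower number from compound 2 to compound 3 (0.03 log units; within the scatter). Compound 3 is accordingly expected to give 8000 nM, within 3000 nM to 20000 nM.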

Compound 3, half-maximal inhibitory concentration: 16600 nM
For compound 3 the middle estimate is 2.1-fold (0.32 log units) below the measured one, within the range that was stated.
By their numbers in this assay, from the lowest: compounds 1, 2 and 3 (each within the scatter of the next, the first and the last beyond it).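

In this assay, 2-methoxyphenyl in place of 3-bromophenyl on a double-bonded chain carbon bound to a double-bonded chain carbon gives a 1.9-fold higher number from compound 2 to compound 3 (0.29 log units; within the scatter). Within the data shown here, this is the first single change read at this place: it swaps bromine for a methoxy group, adds one hydrogen-bond acceptor, and yields no step beyond the scatter. No measurement bears on why the step has this size.

The compounds shown leave open whether an amine or a carboxylic acid on this ring would move the number beyond the scatter. Compound 1 differs from both in more than one place, so it cannot settle this.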